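A Methyl Moved From the Side Chain to the Ring

The source may hold more compounds than are shown below. What is called first, only, known or untested is meant among the compounds shown, and "the series" means these compounds.

Compound 1 `CC(C(=O)Nc1cccc(Cl)c1)N1C(=O)CCC1=O` was tested in a functional assay on the whole organism (strain Swiss) with Mus musculus as the target (on this read-out lower numbers stand for an effect already at smaller amounts and higher numbers for an effect only at larger amounts of compound), where compound 1 gives 74.5 mg/kg. Among the compounds with values here, it is the higher of the two numbers so far, though its only neighbour, compound 2 `CCC(C(=O)Nc1cccc(Cl)c1)N1C(=O)CCC1=O`, which gives 43.4 mg/kg, lies within the usual scatter of it. Within the data shown here, that single measured step, a 1.7-fold lower number from compound 1 to compound 2 (0.23 log units; within the scatter), is the only guide at hand. Among the measured compounds shown here, compound 3 `CC1CC(=O)N(C(C)C(=O)Nc2cccc(Cl)c2)C1=O` differs from compound 1 by methyl in place of hydrogen on a saturated ring carbon, a methyl at a different place from the one in compound 2, so the measured step bears on it only loosely. No step beyond the scatter is expected, and compound 3 is estimated at 60 mg/kg, within 30 mg/kg to 130 mg/kg, meaning a 1.2-fold lower number from compound 1 to compound 3 (0.09 log units; within the scatter).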

Compound 3, dose for half-maximal effect: 88.2 mg/kg
Beside the measured number, compound 3's estimate is 1.5-fold (0.17 log units) below it, within the range that was stated.
By their numbers in this assay, from the lowest: compounds 2, 1 and 3 (each within the scatter of the next, the first and the last beyond it).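

In this assay, the methyl on the saturated ring carbon gives a 1.2-fold higher number from compound 1 to compound 3 (0.07 log units; within the scatter). This ring position now has a measured step of its own, and a single methyl there leaves compound 3 indistinguishable from compound 1 on this read-out. No other data bear on this result.

From the compounds shown here alone, whether a larger group on the same ring carbon, such as an ethyl or a phenyl, would produce a step beyond the scatter remains open. So does the effect of a hydroxyl or of a second methyl there.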